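Aryl-swap series at the saturated ring carbon: furan-2-yl

A few compounds are considered here, and "the series" means these few. Any claim that something is new, unique, unknown or untested is made for them only; others in the source may bear on it.

Three compounds share one core and differ only in the aryl group on the saturated ring carbon. Compound 1 `Cc1ccc(C2C(C#N)=C(N)N(c3ccc(S(N)(=O)=O)cc3)C3=C2C(=O)CCC3)cc1` carries a methyl on its aromatic carbon; in a functional assay on Ehrlich cells (Mus musculus) for antiproliferative activity, read by trypan blue exclusion, with a stated time of 2 h, tested at 100 ug/mL (a higher number here means a stronger effect of the compound at the concentration tested, a lower number a weaker effect), compound 1 gives 100%. Compound 2 `N#CC1=C(N)N(c2ccc(S(N)(=O)=O)cc2)C2=C(C(=O)CCC2)C1c1ccc(O)cc1` carries hydroxy there, and compound 2 gives 100%. Compound 3 `N#CC1=C(N)N(c2ccc(S(N)(=O)=O)cc2)C2=C(C(=O)CCC2)C1c1ccc([N+](=O)[O-])cc1` carries nitro, and compound 3 gives 100%. The steps are no change at the digits printed from compound 1 to compound 2 (within the scatter), no change at the digits printed from compound 1 to compound 3 (within the scatter) and no change at the digits printed from compound 2 to compound 3 (within the scatter). Compound 3 therefore stands level with compound 1 and compound 2 at the digits shown; all three sit at the same reading.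

Compound 4 `N#CC1=C(N)N(c2ccc(S(N)(=O)=O)cc2)C2=C(C(=O)CCC2)C1c1ccco1` is not yet measured. It differs from compound 3 by furan-2-yl in place of 4-nitrophenyl on a saturated ring carbon. Among the measured compounds shown here, no measured step exchanges the aromatic ring itself; the three steps only vary the substituent on it and none moved beyond the scatter. The expectation rests on that, so the step from compound 3 to compound 4 is expected to be no change at the digits printed from compound 3 to compound 4 (within the scatter). Compound 4 is estimated at 100%, between 80% and 100%.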

Compound 4, a percentage reported as activity, at one concentration (the size of the read-out at that concentration, not a potency): 10%
Compound 4: middle estimate off by 90 percentage points, on the high side; the whole stated range lies above it.
By their numbers in this assay, from the lowest: compound 4; then compounds 1, 2 and 3 (each within the scatter of the next).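

In this assay the aryl group on the saturated ring carbon proves not to be freely exchangeable: substituents on the six-membered aromatic ring left the reading unmoved, but furan-2-yl in place of that ring gives a number 90 percentage points lower from compound 3 to compound 4 (beyond the scatter), with a number 90 percentage points lower from compound 2 to compound 4 (beyond the scatter) and a number 90 percentage points lower from compound 1 to compound 4 (beyond the scatter). Compound 4 alone carries a five-membered aromatic ring with a hetero atom and no further substituent, so these features change together and the steps cannot separate them. Nothing available gives a reason for the drop.

Open, as far as these compounds go, is whether unsubstituted phenyl, thiophen-2-yl or a pyridinyl group at this carbon keeps the reading of compound 1, compound 2 and compound 3 or falls towards that of compound 4. Also open, from the compounds shown here alone, is whether those three aryl compounds stay level at concentrations lower than the one tested.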